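The compounds below may be only part of what the source reports. "The series", "measured", "known", "first", "only" and "open" are said of these compounds alone.

In a functional assay on A549 cells (Homo sapiens) for cytotoxicity, read by MTT assay, with a stated time of 48 h (on this read-out lower numbers stand for stronger inhibition and higher numbers for weaker inhibition), compound 2 `CCOC(=O)[C@@]1(C(=O)Nc2ccccc2Cl)C[C@@H]1c1cc(OC)c(OC)c(OC)c1` gives 29000 nM, and its mirror image, compound 3 `CCOC(=O)[C@]1(C(=O)Nc2ccccc2Cl)C[C@H]1c1cc(OC)c(OC)c(OC)c1`, gives 13400 nM, so compound 2 holds the higher of the two numbers. That step, a 2.2-fold lower number from compound 2 to compound 3 (0.34 log units; beyond the scatter), comes with the fact that compounds 2 and 3 differ only in the configuration as drawn, so it sets no size for an exchange of groups. Compound 1 `COc1cc([C@H]2C[C@@]2(CO)C(=O)Nc2ccccc2)cc(OC)c1OC`, which bears hydroxymethyl, stands at a limit, > 100000 nM, and this points towards a higher number rather than a lower one. Compound 4 `COc1cc([C@H]2C[C@@]2(CO)C(=O)Nc2ccccc2Cl)cc(OC)c1OC` differs from compound 2 as follows: hydroxymethyl in place of ethoxycarbonyl on a saturated ring carbon. A modest rise in this assay is therefore expected, the estimated step being a 2.1-fold higher number from compound 2 to compound 4 (0.32 log units; beyond the scatter). For compound 4 the expected value is 60000 nM, with an estimated range of 20000 nM to 100000 nM.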

Compound 4, half-maximal inhibitory concentration: > 100000 nM
Compound 4 gave a limit, no number; the forecaster's own chance of this, stated with the estimate: 40%; at least 1.6-fold (0.22 log units) between middle value and limit.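

In this assay, among the compounds shown here, hydroxymethyl in place of ethoxycarbonyl on a saturated ring carbon gives the first size for an exchange of groups at this position: an at least 3.4-fold higher number from compound 2 to compound 4 (0.53 log units; beyond the scatter). The mirror-image pair, compounds 2 and 3, could not give such a size. The step between compounds 1 and 4 cannot be read because both stand at a limit: the limit of > 100000 nM in this assay, at which 2 of the 4 values shown sit.

The compounds shown leave open whether a carboxylic acid or a longer ester chain at this ring carbon would give a number near that of compound 2. They also leave open how the mirror image of compound 4 would read.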